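Swapping a butyl chain for phenyl: solubility outlook

A few compounds are considered here, and "the series" means these few. Any claim that something is new, unique, unknown or untested is made for them only; others in the source may bear on it.

Compound 2, `CCCCNc1nc(NCc2ccccc2)nc2ccccc12`, sits at the upper limit of a physicochemical assay for solubility, at pH 2; a lower number here means a less soluble compound, a higher number a more soluble compound: its reading of >= 30000 nM is a limit of the assay rather than a number. Compound 1, `CNc1nc(NCc2ccccc2)nc2ccccc12`, likewise gives a limit there, >= 30000 nM. Both readings stand at the limit of >= 30000 nM in this assay, at which 2 of the 2 values shown sit. Within the data shown here, the only measured step, a step that the two limits leave unreadable from compound 1 to compound 2, therefore cannot be sized. Compound 3, `c1ccc(CNc2nc(Nc3ccccc3)c3ccccc3n2)cc1`, differs from compound 2 by phenyl in place of butyl on a nitrogen on an aromatic ring. Among the measured compounds shown here, no measured step bears on this change, so its size and direction remain open. For compound 3 the expected value in this assay is 30000 nM, within 5000 nM to 30000 nM. The step this expectation implies is a number no higher from compound 2 to compound 3 (the limit leaves the size open).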

Compound 3, solubility: >= 30000 nM
Compound 3: only a limit was reported; the forecaster's own chance of this, stated with the estimate: 60%; the middle value sits exactly at the limit.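

In this assay compound 3 gives >= 30000 nM as a limit, so no step among compound 1, compound 2 and compound 3 can be read: the limit of >= 30000 nM in this assay, at which 3 of the 3 values shown sit.

From the compounds shown here alone, whether methyl, butyl or phenyl on that nitrogen makes any difference to solubility stays open.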